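The source may report more compounds than this note shows. Statements on the series, on what has been measured and on what is new or still open speak of the compounds shown alone.

Of the compounds shown here, three built on one shared core have been tested in a functional assay on A549 cells (Homo sapiens) for inhibition, read by sulforhodamine B assay, with a stated time of 48 h; a lower number here means a stronger inhibitor of growth, a higher number a weaker inhibitor of growth. Compound 1 `CCOC(=O)[C@H](CCC(=O)O)NC(=O)c1ccc(CNc2nc3cc(N)cc(N)c3nc2-c2ccccc2)cc1` gives < 100000 nM; that value is a limit of the measurement rather than a number, and it stands at the limit of < 100000 nM in this assay, at which 1 of the 3 values shown sits. Compound 2 `Nc1cc(N)c2nc(-c3ccccc3)c(NCc3ccc(Cl)c(Cl)c3)nc2c1` gives 10700 nM in this assay. Compound 3 `CCOC(=O)[C@H](CCC(=O)O)NC(=O)c1ccc(Sc2nc3cc(N)cc(N)c3nc2-c2ccccc2)cc1` gives 20400 nM in this assay. Of the two compounds with a number, compound 2 has the lower one, but its gap to compound 3 lies within the scatter, so the two cannot be told apart.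

Compound 4 `COc1ccc(CNc2nc3cc(N)cc(N)c3nc2-c2ccccc2)cc1` has not yet been measured. It differs from compound 2 in one place: 4-methoxyphenyl in place of 3,4-dichlorophenyl on a saturated chain carbon bound to a nitrogen on an aromatic ring. Within the data shown here, no pair of measured compounds shows this kind of change, so its effect cannot be read from the numbers at hand. The step expected in this assay is a 2.3-fold higher number from compound 2 to compound 4 (0.37 log units; beyond the scatter), a modest move toward a weaker inhibitor, though a step of similar size the other way, or none beyond the scatter, would not surprise. Compound 4 is expected to give 25000 nM in this assay, within a range from 8000 nM to 80000 nM.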

Compound 4, concentration for 50% growth inhibition: 21400 nM
Estimate against measurement, compound 4: 1.2-fold (0.07 log units) above, and the stated range covers the measured number.
By their numbers in this assay, from the lowest: compounds 2, 3 and 4 (each within the scatter of the next).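

Among these compounds, this change gives the first comparison in the set between compounds that differ in one place: a 2.0-fold higher number from compound 2 to compound 4 (0.30 log units; within the scatter) in this assay, so the two compounds cannot be told apart. On a saturated chain carbon bound to a nitrogen on an aromatic ring, 3,4-dichlorophenyl and 4-methoxyphenyl therefore read alike here, although only the entering group carries a hydrogen-bond acceptor. Nothing measured here offers a reason for this step.

This single pair cannot show how far the position accepts other groups, such as an unsubstituted benzyl, a benzyl bearing a carboxylic acid or an amine, or a longer chain between the ring and the nitrogen. It also leaves open whether 4-methoxybenzyl and 3,4-dichlorobenzyl would still match on a core carrying other groups.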